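A few compounds are considered here, and "the series" means these few. Any claim that something is new, unique, unknown or untested is made for them only; others in the source may bear on it.

Measured in a functional assay on PC-9 cells (Homo sapiens) for inhibition, read by MTT assay, with a stated time of 72 h; on this read-out lower numbers stand for stronger inhibition and higher numbers for weaker inhibition:
Compound 1 `Cc1cc(Nc2cc(-c3ccccc3)[nH]n2)n2nc(SCc3ccccc3Br)nc2n1`: 5630 nM
Compound 2 `Cc1cc(Nc2cc(-c3ccccc3)[nH]n2)n2nc(SCc3ccc(Cl)cc3)nc2n1`: 6710 nM
Compound 3 `C=CCSc1nc2nc(C)cc(Nc3cc(-c4ccccc4)[nH]n3)n2n1`: > 50000 nM

Compound 3 stands at the limit of > 50000 nM in this assay, at which 1 of the 3 values shown sits, so it has a limit and not a number. Compound 4 `Cc1cc(Nc2cc(-c3ccccc3)[nH]n2)n2nc(SCc3cccc4ccccc34)nc2n1` differs from compound 3 as follows: naphthalen-1-yl in place of vinyl on a saturated chain carbon bound to a sulfur. Among the compounds with values here, two measured steps bear on this change, each replacing an aromatic ring with vinyl on that carbon. These are an at least 8.8-fold higher number from compound 1 to compound 3 (0.94 log units; beyond the scatter) and an at least 7.4-fold higher number from compound 2 to compound 3 (0.87 log units; beyond the scatter). The two aryl groups themselves differ little, with a 1.2-fold higher number from compound 1 to compound 2 (0.08 log units; within the scatter). A step of similar size in the opposite direction, towards a lower number, is therefore expected in this assay. The estimated step is an at least 10-fold lower number from compound 3 to compound 4 (1.00 log units; beyond the scatter). For compound 4 the estimated value is 5000 nM, with an expected range of 1500 nM to 20000 nM.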

Compound 4, half-maximal inhibitory concentration: 3950 nM
Compound 4: the middle estimate sits 1.3-fold (0.10 log units) above what was measured, and the stated range covers the measured number.
By their numbers in this assay, from the lowest: compounds 4, 1 and 2 (each within the scatter of the next). At a limit, above all of these: compound 3.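

In this assay, naphthalen-1-yl confirms the gap from vinyl on the saturated chain carbon bound to a sulfur, with an at least 12-fold lower number from compound 3 to compound 4 (1.10 log units; beyond the scatter), though this step starts from a limit and not a number: the limit of > 50000 nM in this assay, at which 1 of the 4 values shown sits.

Having 2 six-membered aromatic rings rather than one separates nothing here, with a 1.7-fold lower number from compound 2 to compound 4 (0.23 log units; within the scatter) and a 1.4-fold lower number from compound 1 to compound 4 (0.15 log units; within the scatter), both within the scatter.

As far as these compounds go, it remains open whether a cyclohexyl ring or a longer saturated chain on that carbon would match the aromatic groups or fall with vinyl. From the compounds shown here alone, the effect of an amine or a carboxylic acid on the aromatic ring also stays open.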